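Swapping cyano for chloro on the shared core

The source may hold more compounds than are shown below. What is called first, only, known or untested is meant among the compounds shown, and "the series" means these compounds.

In a functional assay on cells (Mast cell, Rattus norvegicus) for inhibition, with a stated time of 15 min (on this read-out higher numbers stand for an effect only at larger amounts of compound and lower numbers for an effect already at smaller amounts), compound 1 `O=C(Nc1nnn[nH]1)c1cc(=O)c2ccccc2o1` gives 0.08 ug/mL. Compound 2 `Cn1nnnc1NC(=O)c1cc(=O)c2ccccc2o1` gives > 18 ug/mL, and this value is a limit, not a number. Among the compounds with values here, compound 3 `N#Cc1ccc2oc(C(=O)Nc3nnn[nH]3)cc(=O)c2c1` gives 2.3 ug/mL, the higher of the two actual numbers, and its only numerical neighbour lies well below it: a 29-fold higher number from compound 1 to compound 3 (1.46 log units; beyond the scatter).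

Compound 4 `O=C(Nc1nnn[nH]1)c1cc(=O)c2cc(Cl)ccc2o1` has not yet been measured. It differs from compound 3 as follows: chloro in place of cyano on an aromatic carbon. So compound 4 carries chloro where compound 3 carries cyano.

The step that bears most directly on this change is the one that introduced the cyano group, which was large. The other measured step, an at least 220-fold higher number from compound 1 to compound 2 (2.35 log units; beyond the scatter), concerns methyl on an aromatic nitrogen and is a different kind of change, so it offers little guidance here. Within the data shown here, no measured compound carries chloro, so the forecast rests on a single comparison. Removing cyano from compound 3 leaves the hydrogen of compound 1, and chloro is expected to recover part of that gap, though not all of it. The expected change is a 3.8-fold lower number from compound 3 to compound 4 (0.58 log units; beyond the scatter), a moderate move towards a lower number. Compound 4 is estimated at 0.6 ug/mL, with an expected range from 0.08 ug/mL to 3 ug/mL.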

Compound 4, concentration for half-maximal effect: 0.75 ug/mL
Beside the measured number, compound 4's estimate is 1.3-fold (0.10 log units) below it; low and high end bracket the measured number.
By their numbers in this assay, from the lowest: compound 1; then compound 4; then compound 3. At a limit, above all of these: compound 2.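

In this assay, compound 4 shows that what stands on this aromatic carbon of the shared core matters beyond the simple presence of a substituent, as the exchange of cyano for chloro alone moves the read-out: a 3.1-fold lower number from compound 3 to compound 4 (0.49 log units; beyond the scatter) is a step beyond the usual scatter, though a modest one. Chloro does not return the read-out to the level seen with hydrogen, and a 9.4-fold higher number from compound 1 to compound 4 (0.97 log units; beyond the scatter) makes this a second substituent at this carbon, after cyano, that stands with a higher number than hydrogen, where the earlier compounds could show this for cyano alone. Nothing measured here accounts for the difference between chloro and cyano at this carbon.

With only hydrogen, cyano and chloro shown on this carbon, it remains open whether a different group, such as an amine, a methoxy group or a carboxylic acid, would come closer to hydrogen or fall further from it. As far as these compounds go, it also remains open whether chloro on any other aromatic carbon of this ring would give a similar step, and whether methyl on the aromatic nitrogen would have the same effect in a compound that carries chloro.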